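The compounds below may be only part of what the source reports. "The series", "measured", "known", "first", "only" and "open" are said of these compounds alone.

Measured so far in a functional assay for antagonist activity, with Cavia porcellus as the target (a higher number here means a weaker inhibitor, a lower number a stronger inhibitor), are two compounds.
- compound 1 `CN(C)CC#CCCC1(C(O)(c2ccccc2)c2ccccc2)SCCCS1` gives (1810 nM)
- compound 2 `OC(c1ccccc1)(c1ccccc1)C1(CCC#CCN2CCCCC2)SCCCS1` gives (1000 nM)

Compound 2 has the lower of the two numbers, but its gap to compound 1 lies within the scatter. Compound 3 `CCN(CC)CC#CCCCC1(C(O)(c2ccccc2)c2ccccc2)SCCCS1` departs from compound 2 by one change (4-(diethylamino)but-2-yn-1-yl in place of 3-(piperidin-1-yl)prop-1-yn-1-yl on a saturated chain carbon, two bonds along the chain from a saturated ring carbon), on a saturated chain carbon, two bonds along the chain from a saturated ring carbon. Going by the values given here, the only measured step (a 1.8-fold lower number from compound 1 to compound 2 (0.26 log units; within the scatter)) exchanged dimethylamino for piperidin-1-yl and stayed within the scatter. Among the compounds with values here, no measured step covers 4-(diethylamino)but-2-yn-1-yl, so the range stays wide. In this assay no step beyond the scatter is expected, in either direction. Compound 3 is expected at 1400 nM (range 450 nM to 4500 nM as estimated). This estimate means an expected step (a 1.4-fold higher number from compound 2 to compound 3 (0.15 log units; within the scatter)).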

Compound 3, antagonist equilibrium constant: 810 nM
For compound 3 the middle estimate is 1.7-fold (0.24 log units) above the measured one; the measured number falls inside the stated range.
By their numbers in this assay, from the lowest: compounds 3, 2 and 1 (each within the scatter of the next, the first and the last beyond it).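

In this assay the ring-free 4-(diethylamino)but-2-yn-1-yl group stands in for 3-(piperidin-1-yl)prop-1-yn-1-yl with a 1.2-fold lower number from compound 2 to compound 3 (0.09 log units; within the scatter), so the piperidine ring is not required at this position. Going by these compounds alone, putting the same group in place of 3-(dimethylamino)prop-1-yn-1-yl gives a 2.2-fold lower number from compound 1 to compound 3 (0.35 log units; beyond the scatter), the only step so far beyond the scatter, and a modest one. No evidence is available that would explain these steps. Still open, on these data alone, is how a pyrrolidin-1-yl or morpholin-4-yl group in place of diethylamino, or a longer chain carrying it, would read in this assay.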